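Swapping difluorophenyl isomers in the series

The compounds below may be only part of what the source reports. "The series", "measured", "known", "first", "only" and "open" are said of these compounds alone.

In an ADME assay on BJ cells (Homo sapiens) for cytotoxicity, with a stated time of 72 h (a lower number here means that less compound is needed, a higher number that more compound is needed for the effect), compound 2 `C=C[C@@](C)(/C=C/c1ccc(Nc2ccc(F)c(F)c2)cc1)CCC=C(C)C` gives > 36600 nM, which is a limit and not a number. Compound 1 `C=C[C@@](C)(/C=C/c1ccc(OCc2ccccc2)cc1)CCC=C(C)C` gives > 36600 nM, again a limit. For the measured compounds named here, the only measured step bearing on the change is a step that the two limits leave unreadable from compound 1 to compound 2, and the evidence is the limit of > 36600 nM in this assay, at which 2 of the 2 values shown sit. Compound 3 `C=C[C@@](C)(/C=C/c1ccc(Nc2cc(F)cc(F)c2)cc1)CCC=C(C)C` carries 3,5-difluorophenyl in place of 3,4-difluorophenyl on a nitrogen on an aromatic ring. With no readable step to go on, no shift beyond the scatter is expected in this assay, and the expected step is a number no higher from compound 2 to compound 3 (the limit leaves the size open). For compound 3 the estimate is 36600 nM, ranging from 18000 nM to 60000 nM, and another limit is the likely report.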

Compound 3, half-maximal effective concentration: > 36600 nM
Compound 3: no number, only a limit; the forecaster's own chance of this, stated with the estimate: 85%; the middle value sits exactly at the limit.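

Compound 3 gives > 36600 nM in this assay, a limit and not a number. Its steps from compound 1 and compound 2 therefore cannot be read: the limit of > 36600 nM in this assay, at which 3 of the 3 values shown sit.

From the compounds shown here alone, whether compound 1, compound 2 and compound 3 differ at all in this assay remains open.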